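Ring-nitrogen substituent and cell inhibition in the pyrazoline series

The source may report more compounds than this note shows. Statements on the series, on what has been measured and on what is new or still open speak of the compounds shown alone.

Measured compounds:
compound 1, `CC(=O)N1N=C(c2ccc(N3CCN(C)CC3)cc2)CC1c1ccc(N(C)C)cc1`, -1.9% in a functional assay on NCI-H1975 cells (Homo sapiens) for inhibition, read by sulforhodamine B assay, tested at 10 uM; a lower number here means less inhibition, a higher number more inhibition at the concentration tested (going by the name of the read-out)
compound 2, `CN1CCN(c2ccc(C3=NN(C(=O)CCCl)C(c4ccc(N(C)C)cc4)C3)cc2)CC1`, -0.2%
compound 3, `CN1CCN(c2ccc(C3=NN(C(=O)c4ccc(F)cc4)C(c4ccc(N(C)C)cc4)C3)cc2)CC1`, 32.2%

Compound 3 stands highest of the three numbers. The step from compound 2 to compound 3 and the step from compound 1 to compound 3 are both beyond the scatter. Compound 4, `CN1CCN(c2ccc(C3=NN(S(C)(=O)=O)C(c4ccc(N(C)C)cc4)C3)cc2)CC1`, is not yet measured. It differs from compound 3 in one place: methylsulfonyl in place of (4-fluorophenyl)carbonyl on an amine nitrogen in a ring.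

For the measured compounds named here, two measured steps bear on this change, both touching the same ring nitrogen substituent. The step of a number 34.1 percentage points higher from compound 1 to compound 3 (beyond the scatter) and the step of a number 32.4 percentage points higher from compound 2 to compound 3 (beyond the scatter) show that the (4-fluorophenyl)carbonyl group carries a large gain over the two small groups, while the step of a number 1.7 percentage points higher from compound 1 to compound 2 (within the scatter) shows no difference between the two small groups. Compound 4 again carries a small group, so the gain seen with compound 3 is expected to be lost; a step of about a number 27.2 percentage points lower from compound 3 to compound 4 (beyond the scatter) is expected. Going by the values given here, no measured compound carries a sulfonyl, so the estimate is loose. For compound 4 the expected value is 5%, with a range from -10% to 25%.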

Compound 4, a percentage reported as inhibition, at one concentration (the size of the read-out at that concentration, not a potency): -1.3%
Compound 4: the middle estimate sits 6.3 percentage points above what was measured; the range from low to high includes it.
By their numbers in this assay, from the lowest: compounds 1, 4 and 2 (each within the scatter of the next); then compound 3.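

In this assay the change to methylsulfonyl gives a number 33.5 percentage points lower from compound 3 to compound 4 (beyond the scatter), so a sulfonyl on the ring nitrogen does not keep the level of compound 3. The same group gives a number 1.1 percentage points lower from compound 2 to compound 4 (within the scatter) and a number 0.6 percentage points higher from compound 1 to compound 4 (within the scatter), which places it with (2-chloroethyl)carbonyl and acetyl; among these four compounds, only compound 3, whose substituent holds a six-membered aromatic ring, stands apart, and none goes against this. Nothing available explains why the (4-fluorophenyl)carbonyl group stands apart.

Whether the aromatic ring, the fluorine or the carbonyl accounts for the level of compound 3 stays open. An unsubstituted benzoyl group would separate the fluorine from the ring, and a phenylsulfonyl group would show whether the ring also works on a sulfonyl.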